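Inverting the hydroxyl-bearing stereocentre of compound 2

The source may hold more compounds than are shown below. What is called first, only, known or untested is meant among the compounds shown, and "the series" means these compounds.

Compound 1 `O=C(/C=C/[C@@H](O)Cc1ccccc1)CCc1ccccc1`: 355000 nM
Compound 2 `COc1ccc(CCC(=O)/C=C/[C@H](O)Cc2ccccc2)cc1OC`: 32600 nM

In a functional assay on HepG2 cells (Homo sapiens) for antiproliferative activity, read by MTT assay, with a stated time of 48 h (a higher number here means a weaker inhibitor, a lower number a stronger inhibitor), compound 1 gives 355000 nM and compound 2 gives 32600 nM. Compound 2 holds the lower of the two numbers, and compound 1 stands beyond the scatter above it.

Compound 3 `COc1ccc(CCC(=O)/C=C/[C@@H](O)Cc2ccccc2)cc1OC` differs from compound 2 only in this way: the two compounds have the same atoms and bonds and differ only in configuration as drawn: 1 of 2 stereo elements differ; a stereocentre at a saturated chain carbon is drawn R in compound 2 and S in compound 3. Among the measured compounds shown here, no pair of measured compounds isolates such a change, so its direction is not fixed by the data. The expected step is a 1.7-fold higher number from compound 2 to compound 3 (0.23 log units; within the scatter), modest and toward a higher number. Compound 3 is therefore estimated at 55000 nM, with a range from 12000 nM to 250000 nM.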

Compound 3, half-maximal inhibitory concentration: 53500 nM
Compound 3: the middle estimate sits 1.0-fold (0.01 log units) above what was measured; the measured number falls inside the stated range.
By their numbers in this assay, from the lowest: compounds 2 and 3 (each within the scatter of the next); then compound 1.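

Inverting the stereocentre at this saturated chain carbon gives a 1.6-fold higher number from compound 2 to compound 3 (0.22 log units; within the scatter) in this assay, so the R and S drawings cannot be told apart in this read-out. The earlier compounds held no pair that isolated configuration at this position, and this pair does: the fact that compounds 2 and 3 differ only in the configuration as drawn

From the compounds shown here alone, it remains open whether configuration at this carbon stays this silent when the methoxy groups of compounds 2 and 3 are replaced by other groups. Going by these compounds, the effect of an amine or a carboxylic acid in place of the hydroxyl also remains open.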